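The source may hold more compounds than are shown below. What is called first, only, known or untested is meant among the compounds shown, and "the series" means these compounds.

Measured in an assay for inhibition of inositol hexakisphosphate kinase 2 (Homo sapiens), read by colorimetric assay, coupled enzyme assay and malachite green, with a stated time of 120 min, in the presence of a further agent that is not named here; a higher number here means a weaker inhibitor, a lower number a stronger inhibitor:
compound 1 `O=C(O)c1ccc2noc(-c3ccc(-c4cccnc4)cc3)c2c1` gives 54 nM;
compound 2 `O=C(O)c1ccc2noc(-c3ccc(Oc4ccccc4)cc3)c2c1` gives 280 nM;
compound 3 `O=C(O)c1ccc2noc(-c3ccc(N4CCCC4=O)cc3)c2c1` gives 480 nM.

Compound 3 carries the highest number of the three. Its gap to compound 2 is small, a 1.7-fold higher number from compound 2 to compound 3 (0.23 log units; within the scatter), so no order between these two can be read; its gap to compound 1, an 8.9-fold higher number from compound 1 to compound 3 (0.95 log units; beyond the scatter), is clear, as is a 5.2-fold higher number from compound 1 to compound 2 (0.71 log units; beyond the scatter).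

Compound 4 `O=C(O)c1ccc2noc(-c3ccc(NC(=O)c4ccccc4)cc3)c2c1` is the next point in the series. The change from compound 3 is benzamido in place of 2-oxopyrrolidin-1-yl on an aromatic carbon. Among the measured compounds shown here, no measured step exchanges these two groups directly. For the measured compounds named here, the steps that bear on it are a 1.7-fold higher number from compound 2 to compound 3 (0.23 log units; within the scatter), which shows that an oxygen-linked aromatic ring and a five-membered lactam give numbers within the scatter of each other, and the two steps from compound 1, which show that only pyridin-3-yl stands apart. Benzamido carries both a six-membered aromatic ring of carbon only and a carbonyl, so a step of the size a 1.6-fold lower number from compound 3 to compound 4 (0.20 log units; within the scatter) is expected, that is none beyond the scatter, with a slight lean toward a lower number. Compound 4 is estimated at 300 nM, range 90 nM to 1000 nM.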

Compound 4, half-maximal inhibitory concentration: 580 nM
Compound 4: middle estimate off by 1.9-fold (0.29 log units), on the low side; the measured number falls inside the stated range.
By their numbers in this assay, from the lowest: compound 1; then compounds 2, 3 and 4 (each within the scatter of the next, the first and the last beyond it).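

In this assay, benzamido, with its amide hydrogen and its six-membered aromatic ring of carbon only, cannot be told apart from 2-oxopyrrolidin-1-yl on this aromatic carbon, with a 1.2-fold higher number from compound 3 to compound 4 (0.08 log units; within the scatter). Benzamido and phenoxy are only just separated, with a 2.1-fold higher number from compound 2 to compound 4 (0.32 log units; beyond the scatter), whereas an 11-fold higher number from compound 1 to compound 4 (1.03 log units; beyond the scatter) confirms that pyridin-3-yl stands apart from all three other groups shown. No measurement shown here accounts for these differences.

Still open, from the compounds shown here alone, is whether the lower number of compound 1 belongs to the ring nitrogen of pyridin-3-yl or to any aromatic ring attached directly at this place, a question that a plain phenyl group would address. Also open, going by these compounds, is how a saturated amine such as morpholine, or a longer chain, would compare on this aromatic carbon.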